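The source may report more compounds than this note shows. Statements on the series, on what has been measured and on what is new or still open speak of the compounds shown alone.

Working notes on the series. Compound 1 `O=C(CC(CC(=O)NC1Cc2ccccc2C1)c1ccc(Cl)cc1)NCCN1CCCCC1` serves as the reference point. In a functional assay on L02 cells (Homo sapiens) for inhibition (a higher number here means a weaker inhibitor, a lower number a stronger inhibitor), compound 1 gives 70400 nM. Compound 2 `O=C(CC(CC(=O)NC1Cc2ccccc2C1)c1ccccc1)NCCN1CCCCC1` carries the change (hydrogen in place of chloro on an aromatic carbon). For compound 2 only a limit of the assay is reported, > 100000 nM, so its number is not known. The measured step is accordingly a floor: an at least 1.4-fold higher number from compound 1 to compound 2 (0.15 log units; that floor lies within the scatter). Compound 3 `CCNCCNC(=O)CC(CC(=O)N(CC)C1Cc2ccccc2C1)c1ccc(Cl)cc1` has another core; how its core differs from that of compound 1 is not broken down here. In this assay compound 3 gives 66200 nM, and against compound 1 the two values lie within the scatter of each other.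

Compound 4 `CCNCCNC(=O)CC(CC(=O)N(CC)C1Cc2ccccc2C1)c1ccccc1` is not yet measured. It carries the change (hydrogen in place of chloro on an aromatic carbon), the same change already made from compound 1 to compound 2, at the same place in both cases. The expectation for compound 4 rests on that earlier pair: the expected size is a 1.7-fold higher number from compound 3 to compound 4 (0.22 log units; within the scatter), beside the measured at least 1.4-fold higher number from compound 1 to compound 2 (0.15 log units; that floor lies within the scatter), with the caution that the earlier step is only a floor because of the limit of > 100000 nM in this assay, at which 1 of the 3 values shown sits. Compound 4 is expected at 110000 nM. The estimated range for compound 4 runs from 60000 nM to 250000 nM. Given where compound 3 stands, with 66200 nM, the upper end of that range is not far away. For compound 4 a report of only a limit of the assay is therefore a real possibility.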

Compound 4, half-maximal inhibitory concentration: > 100000 nM
Compound 4 gave a limit, no number (the forecaster's own chance of this, stated with the estimate: 55%); the middle value does not contradict the limit.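

In this assay the change from 4-chlorophenyl to phenyl on the second core gives an at least 1.5-fold higher number from compound 3 to compound 4 (0.17 log units; that floor lies within the scatter), and this floor is all that can be read of the step. Going by these compounds alone, what carries over from one core to the other is only that both phenyl compounds, compound 2 and compound 4, are reported as a limit and not as a number, while the size of the change on each core stays unknown: the same change on two cores in this assay, an at least 1.4-fold higher number (0.15 log units; that floor lies within the scatter) from compound 1 to compound 2 and an at least 1.5-fold higher number (0.17 log units; that floor lies within the scatter) from compound 3 to compound 4; the limit leaves it open whether they differ. With this many values at the limit, the two steps do not show whether removing the chloro changes the result on either core, and they give no measure of how well the step transfers: the limit of > 100000 nM in this assay, at which 2 of the 4 values shown sit.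

The compounds shown carry only chloro or hydrogen at this place on the aromatic ring, so it remains open whether a fluoro, a methoxy or a nitrile there would give a number clearly lower than that of compound 3, at 66200 nM. Also open, on these data alone, is whether the chloro step would read the same with a carboxylic acid or a longer chain at the end of the side chain in place of the amine present in compound 1 and compound 3.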